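The source may hold more compounds than are shown below. What is called first, only, known or untested is meant among the compounds shown, and "the series" means these compounds.

Working notes on the series.

Of the compounds shown here, three sharing one core have been measured in a functional assay on MCF7 cells (Homo sapiens) for inhibition, read by MTT assay, with a stated time of 72 h; a higher number here means a weaker inhibitor, a lower number a stronger inhibitor. Compound 1 `Cc1ccc(NC(=O)c2ccc(/N=N\c3c[nH]c4ccccc34)cc2)cc1` gives 42400 nM. Compound 2 `Cc1ccc(C)c(NC(=O)c2ccc(/N=N\c3c[nH]c4ccccc34)cc2)c1` gives 29900 nM, which is a 1.4-fold lower number from compound 1 to compound 2 (0.15 log units; within the scatter). Compound 3 `COc1ccccc1NC(=O)c1ccc(/N=N\c2c[nH]c3ccccc23)cc1` gives 86500 nM, the highest of the three numbers; the change is a 2.0-fold higher number from compound 1 to compound 3 (0.31 log units; beyond the scatter) and a 2.9-fold higher number from compound 2 to compound 3 (0.46 log units; beyond the scatter), both beyond the scatter, so compound 3 is the weakest inhibitor among the three in this assay.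

Compound 4 `O=C(Nc1ccc(Cl)cc1)c1ccc(/N=N\c2c[nH]c3ccccc23)cc1` has not been measured. It differs from compound 3 by 4-chlorophenyl in place of 2-methoxyphenyl on an amide-type nitrogen. Both measured steps at this position, from compound 1 and from compound 2 to compound 3, show that replacing a methyl-bearing phenyl with 2-methoxyphenyl gives a modestly higher number; the reverse direction, away from 2-methoxyphenyl, is therefore expected to give a modestly lower number. Among the measured compounds shown here, no measured compound carries 4-chlorophenyl, so the size is uncertain. Compound 4 is expected to land near compounds 1 and 2, that is a 2.5-fold lower number from compound 3 to compound 4 (0.39 log units; beyond the scatter), with an estimate of 35000 nM and a range from 15000 nM to 80000 nM.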

Compound 4, half-maximal inhibitory concentration: 107000 nM
Beside the measured number, compound 4's estimate is 3.1-fold (0.49 log units) below it; the measured number lies above the stated range.
By their numbers in this assay, from the lowest: compounds 2 and 1 (each within the scatter of the next); then compounds 3 and 4 (each within the scatter of the next).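

In this assay, leaving 2-methoxyphenyl for 4-chlorophenyl on the amide-type nitrogen gives no resolved change (a 1.2-fold higher number from compound 3 to compound 4 (0.09 log units; within the scatter)), so a phenyl group without methyl at this position is not enough to restore the numbers of the methyl-bearing compounds. The cleanest comparison at this position is now chloro in place of methyl on an aromatic carbon (a 2.5-fold higher number from compound 1 to compound 4 (0.40 log units; beyond the scatter)), and the gap to the 2,5-dimethylphenyl group is of similar order (a 3.6-fold higher number from compound 2 to compound 4 (0.55 log units; beyond the scatter)), so among these four compounds, the two methyl-bearing phenyl groups give the lower numbers and the methoxy and chloro groups the higher ones. No measurement at hand accounts for this difference.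

Open, going by these compounds, is whether the link to methyl holds for other small alkyl groups such as ethyl. Also open, on these data alone, is how an amine or a carboxylic acid on this phenyl ring would read in this assay.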